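Swapping the Chain Tail of Compound 2 for a Pyridine Ester

A few compounds are considered here, and "the series" means these few. Any claim that something is new, unique, unknown or untested is made for them only; others in the source may bear on it.

Of the compounds shown here, two built on one shared core have been measured. Compound 1 `Cc1nc2c(C[S+]([O-])c3ccccc3)cccn2c1C` gives 42% in a functional assay on the whole organism with Rattus norvegicus as the target, with a stated time of 4 h, at a dose of 40 mg/kg by the intraperitoneal route; a higher number here means more inhibition at the dose given (going by the name of the read-out), a lower number less inhibition. Compound 2 `Cc1nc2c(OCc3ccccc3)cccn2c1CCC#N` gives 40% in this assay, and the two numbers lie within the usual scatter of each other, so neither can be ranked above the other on this evidence. Compound 3 `Cc1nc2c(OCc3ccccc3)cccn2c1COC(=O)c1cccnc1` has not yet been measured. It differs from compound 2 in one place: ((pyridin-3-yl)carbonyl)oxy in place of cyanomethyl on a saturated chain carbon bound to an aromatic carbon. Going by the values given here, no single-point step between measured compounds is available here, so no precedent for a change of this kind can be read off. Given that compound 2 gives 40%, the step from compound 2 to compound 3 is expected to be small, a number 2 percentage points lower from compound 2 to compound 3 (within the scatter), with no clear direction beyond the scatter. Compound 3 is estimated at 38%, within a range from 15% to 60%.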

Compound 3, a percentage reported as inhibition, in the whole organism at one dose (the size of the read-out at that dose, not a potency): 87%
Estimate against measurement, compound 3: 49 percentage points below, outside the stated range (above it).
By their numbers in this assay, from the lowest: compounds 2 and 1 (each within the scatter of the next); then compound 3.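

In this assay, the saturated chain carbon bound to an aromatic carbon proves sensitive to what it carries: placing ((pyridin-3-yl)carbonyl)oxy there in place of cyanomethyl gives a number 47 percentage points higher from compound 2 to compound 3 (beyond the scatter) at the one dose tested. The earlier compounds shown here differed in more than one place and offered no single-point step, so they could not show that a change at this position alone can move the read-out this far. No supporting measurement bears on what lies behind the size of this step.

The compounds shown leave open which part of the entering group goes with the step: the pyridine ring, the carbonyl or the linking oxygen. A benzoyloxy group, with a plain phenyl ring in place of the pyridine, or an amide in place of the ester would help separate these parts.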